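Pentyl Amide to Chloropropyl Urea on an Iodophenyl Sulfonate

This account rests on a few compounds, and the source may have more. Where it says the series, first, only, none or still open, it means among the compounds named here.

Measured in a functional assay on HT-1080 cells (Homo sapiens) for antiproliferative activity, read by sulforhodamine B assay, with a stated time of 48 h (on this read-out higher numbers stand for weaker inhibition and lower numbers for stronger inhibition), so far:
compound 1, `CCCCCC(=O)Nc1cccc(S(=O)(=O)Oc2ccccc2C(C)C)c1`: 11000 nM
compound 2, `CCCCCC(=O)Nc1ccc(S(=O)(=O)Oc2ccccc2C(C)C)cc1`: 6300 nM
compound 3, `CCCCCC(=O)Nc1ccc(S(=O)(=O)Oc2ccccc2I)cc1`: 9600 nM

Compound 3 gives the second highest of the three numbers. Its nearest neighbour is compound 1, and the gap between them is within the scatter; its furthest neighbour is compound 2, and that gap too is within the scatter, so the three compounds cannot be placed in an order on these numbers. Among the compounds with values here, the only single-point step recorded so far, a 1.5-fold higher number from compound 2 to compound 3 (0.18 log units; within the scatter), concerns the group on the aromatic carbon of the phenyl sulfonate and is itself within the scatter.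

Compound 4, `O=C(NCCCCl)Nc1ccc(S(=O)(=O)Oc2ccccc2I)cc1`, is not yet measured. It keeps the iodo group and the shared core of compound 3 and changes the chain on the carbonyl carbon: (3-chloropropyl)amino in place of pentyl on a carbonyl carbon. Within the data shown here, no measured pair shows this kind of exchange, so nothing in the data points to a step in either direction beyond the scatter in this assay. The expected step is therefore a 1.1-fold lower number from compound 3 to compound 4 (0.03 log units; within the scatter), and compound 4 is estimated at 9000 nM, with a range from 3000 nM to 27000 nM.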

Compound 4, half-maximal inhibitory concentration: 2800 nM
Beside the measured number, compound 4's estimate is 3.2-fold (0.51 log units) above it; the measured number lies below the stated range.
By their numbers in this assay, from the lowest: compound 4; then compounds 2, 3 and 1 (each within the scatter of the next).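

Within the data shown here, the earlier compounds offered only one single-point step, and it lay within the scatter, so they did not show any place on this series where this assay clearly responds. The chain on the carbonyl carbon is such a place: with the iodo group and the shared core kept, (3-chloropropyl)amino in place of pentyl gives a 3.4-fold lower number from compound 3 to compound 4 (0.54 log units; beyond the scatter) and so a modest but real move towards stronger inhibition. Both groups count 5 heavy atoms, so the change lies in the kind of atoms rather than in that count: the entering group brings a nitrogen, a chlorine and a hydrogen-bond donor that pentyl lacks, and nothing measured here says which of these matters.

From the compounds shown here alone, that question stays open, since a plain propylamino or pentylamino group on the same carbonyl carbon would be needed to separate the contribution of the nitrogen from that of the chlorine, and a 3-bromopropylamino group or a longer chloroalkyl chain would test the halogen and the chain length. Going by these compounds, it is also open whether the same exchange has a similar effect with isopropyl in place of iodo on the phenyl sulfonate.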